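From naphthalen-1-yl to 3,4,5-trimethoxyphenyl on the shared core

The source may report more compounds than this note shows. Statements on the series, on what has been measured and on what is new or still open speak of the compounds shown alone.

Going by the values given here, in a functional assay on COLO 205 cells (Homo sapiens) for inhibition, read by sulforhodamine B assay, with a stated time of 48 h, tested at 50 uM (on this read-out higher numbers stand for more inhibition of growth at the one concentration tested and lower numbers for less inhibition of growth), compound 1 `COc1cc(/C=C/C(=O)/C=C/c2cccc3ccccc23)ccc1OCc1cn(CCOc2cc(=O)oc3ccccc23)nn1` gives 85%, the higher of the two numbers so far, while compound 2 `COc1cc(/C=C/C(=O)/C=C/c2cccc3ccccc23)ccc1OCc1cn(CCCOc2cc(=O)oc3ccccc23)nn1` gives 64%, a gap beyond the scatter. Compound 3 `COc1cc(/C=C/C(=O)/C=C/c2cc(OC)c(OC)c(OC)c2)ccc1OCc1cn(CCOc2cc(=O)oc3ccccc23)nn1` departs from compound 1 on a double-bonded chain carbon bound to a double-bonded chain carbon, where 3,4,5-trimethoxyphenyl takes the place of naphthalen-1-yl: 3,4,5-trimethoxyphenyl in place of naphthalen-1-yl on a double-bonded chain carbon bound to a double-bonded chain carbon. Among the compounds with values here, no measured pair shows this exchange, so the forecast is loose. A moderate fall in this assay is expected, estimated as a number 13 percentage points lower from compound 1 to compound 3 (beyond the scatter). Compound 3 is expected at 72%, with an estimated range of 50% to 90%.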

Compound 3, percent growth inhibition at one concentration: 86%
Compound 3: middle estimate off by 14 percentage points, on the low side, within the range that was stated.
By their numbers in this assay, from the lowest: compound 2; then compounds 1 and 3 (each within the scatter of the next).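

In this assay the exchange gives a number 1 percentage points higher from compound 1 to compound 3 (within the scatter) on a double-bonded chain carbon bound to a double-bonded chain carbon. This position therefore holds its growth inhibition whether it carries two six-membered aromatic rings of carbon only or one such ring bearing the three methoxy groups of 3,4,5-trimethoxyphenyl. Nothing available explains why the two groups read alike. Still open, going by these compounds, is how an amine or a carboxylic acid on the phenyl ring would read here, and whether 3,4,5-trimethoxyphenyl gives the same result on the core of compound 2.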